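Dropping a Ring Nitrogen: Lipophilicity of a Nitrile Series

The source may hold more compounds than are shown below. What is called first, only, known or untested is meant among the compounds shown, and "the series" means these compounds.

Of the compounds shown here, two have been measured in a physicochemical assay for lipophilicity, read by HPLC, at pH 7.5; a higher number here means a more lipophilic compound, a lower number a more polar compound. Compound 1 `CC[C@@H](Nc1c(C#N)c(-c2ccc(-c3ncccc3C)cc2)nc2cnccc12)C(N)=O` gives 2 in this assay. Compound 2 `CCOc1ccccc1-c1ccc(-c2nc3cnccc3c(N[C@H](CC)C(=O)NS(=O)(=O)C3CC3)c2C#N)cc1`, which carries a different side chain and a different outer aryl group, gives 2.3 in this assay; its number lies within the usual scatter of compound 1, so the two cannot be told apart on this evidence.

The step of interest leads from compound 1 to compound 3 `CC[C@@H](Nc1c(C#N)c(-c2ccc(-c3ccccc3C)cc2)nc2cnccc12)C(N)=O`. The change is small and confined to the outer aromatic ring: 2-methylphenyl in place of 3-methylpyridin-2-yl on an aromatic carbon. What is counted there is that a group with one hydrogen-bond acceptor leaves and a group with none enters, while the size of the group is unchanged.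

Going by the values given here, no measured pair in this set shows this particular change, so the size of the step must be estimated. Going from compound 1 to compound 3, an increase in this assay beyond the scatter is expected, of about a number 0.70 log units higher from compound 1 to compound 3 (beyond the scatter). Compound 3 is therefore expected to give about 2.7 in this assay, with a likely range from 2.2 to 3.3.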

Compound 3, distribution coefficient: 3
Beside the measured number, compound 3's estimate is 0.30 log units below it; low and high end bracket the measured number.
By their numbers in this assay, from the lowest: compounds 1 and 2 (each within the scatter of the next); then compound 3.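

With compound 3, the series gains its first measured step between compounds that differ in one place. In this assay, exchanging the 3-methylpyridin-2-yl group for a 2-methylphenyl group, para to a large group, gives a number 1.00 log units higher from compound 1 to compound 3 (beyond the scatter). Both groups are six-membered aromatic rings with no net charge and the same number of heavy atoms, and the count differs in that the ring nitrogen and its hydrogen-bond acceptor are gone, so one exchange of a ring atom in this outer group is enough for a step beyond the scatter; no separate measurement speaks to what lies behind its size.

Going by these compounds alone, this single pair cannot tell whether a step of this size would recur on another side chain, such as the one carried by compound 2. Also open, on these data alone, is where a plain phenyl ring without the methyl, or a phenyl ring carrying an amine or a carboxylic acid instead of the methyl, would fall in this assay.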